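Aryl variation on the shared core: working notes

The compounds below may be only part of what the source reports. "The series", "measured", "known", "first", "only" and "open" are said of these compounds alone.

compound 1 `O=c1ccc2cc(OCc3cc(-c4ccccc4Cl)no3)ccc2o1`, a functional assay on PC-3 cells (Homo sapiens) for cytotoxicity, read by MTT assay, with a stated time of 48 h (on this read-out higher numbers stand for weaker inhibition and lower numbers for stronger inhibition), 18200 nM
compound 2 `O=c1ccc2cc(OCc3cc(-c4ccccc4[N+](=O)[O-])no3)ccc2o1`, this assay 8200 nM
compound 3 `O=c1ccc2cc(OCc3cc(-c4cccc([N+](=O)[O-])c4)no3)ccc2o1`, this assay "not determined" (no result reported)

Compound 3 stands nowhere on the numbers: no value was obtained for it in this assay, so it cannot be placed against compound 1 or compound 2. Compound 4 `N#Cc1ccccc1-c1cc(COc2ccc3oc(=O)ccc3c2)on1` differs from compound 3 by 2-cyanophenyl in place of 3-nitrophenyl on an aromatic carbon. Going by the values given here, no measured step bears directly on this change; the only step in the set, a 2.2-fold lower number from compound 1 to compound 2 (0.35 log units; beyond the scatter), concerns a different exchange at a different place and is modest. With no reference value for compound 3, no step size in this assay can be projected, only a level near the two measured compounds. Compound 4 in this assay is expected around 12000 nM, estimated between 4000 nM and 40000 nM.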

Compound 4, half-maximal inhibitory concentration: 13600 nM
For compound 4 the middle estimate is 1.1-fold (0.05 log units) below the measured one; the measured number falls inside the stated range.
By their numbers in this assay, from the lowest: compounds 2, 4 and 1 (each within the scatter of the next, the first and the last beyond it).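

Cyano in place of nitro gives a 1.7-fold higher number from compound 2 to compound 4 (0.22 log units; within the scatter) and cyano in place of chloro gives a 1.3-fold lower number from compound 1 to compound 4 (0.13 log units; within the scatter), so in this assay the nitrile on the aryl group cannot be told apart from either earlier group, even though those two are separated by a step beyond the scatter. Steps involving compound 3 cannot be read, since it has no value. Nothing measured here speaks to the origin of these steps.

Still open, as far as these compounds go, is how 3-nitrophenyl stands against 2-cyanophenyl at this place. Also open, from the compounds shown here alone, is how an aryl group carrying an amine or a carboxylic acid would read.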